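From vinyl to pent-1-en-1-yl on a carbonyl carbon

The source may hold more compounds than are shown below. What is called first, only, known or untested is meant among the compounds shown, and "the series" means these compounds.

In an ADME assay on L02 cells (Homo sapiens) for inhibition, read by MTT assay, with a stated time of 72 h (on this read-out higher numbers stand for weaker inhibition and lower numbers for stronger inhibition), compound 1 (`C=CC(=O)Nc1cccc(Oc2nc(Nc3cccc(OC)c3)nc3ccsc23)c1`) gives 30300 nM and compound 2 (`C/C=C/C(=O)Nc1cccc(Oc2nc(Nc3cccc(OC)c3)nc3ccsc23)c1`) gives 46000 nM, two values within the scatter of each other. For compound 3 (`CC/C=C/C(=O)Nc1cccc(Oc2nc(Nc3cccc(OC)c3)nc3ccsc23)c1`), the assay reports only a limit, > 50000 nM. Compound 4 (`CCC/C=C/C(=O)Nc1cccc(Oc2nc(Nc3cccc(OC)c3)nc3ccsc23)c1`) carries pent-1-en-1-yl in place of vinyl on a carbonyl carbon. For the measured compounds named here, two measured steps bear on this change: a 1.5-fold higher number from compound 1 to compound 2 (0.18 log units; within the scatter), and an at least 1.6-fold higher number from compound 1 to compound 3 (0.21 log units; that floor lies within the scatter), the latter only a floor. Neither shows a change beyond the scatter, but both point toward a higher number. A small step in that direction is therefore expected, a 1.8-fold higher number from compound 1 to compound 4 (0.26 log units; within the scatter). For compound 4 the estimated value is 55000 nM, with an expected range of 30000 nM to 100000 nM.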

Compound 4, half-maximal inhibitory concentration: > 50000 nM
Compound 4 gave a limit, no number; the forecaster's own chance of this, stated with the estimate: 65%; the middle value lies beyond the limit too.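

In this assay compound 4 returns only a limit, not a number, so pent-1-en-1-yl at this carbonyl carbon gives no readable value. Only floors can be read, and neither lies beyond the scatter: an at least 1.6-fold higher number from compound 1 to compound 4 (0.21 log units; that floor lies within the scatter) and an at least 1.0-fold higher number from compound 2 to compound 4 (0.03 log units; that floor lies within the scatter). The step between compound 3 and compound 4 cannot be read because both stand at the same limit: the limit of > 50000 nM in this assay, at which 2 of the 4 values shown sit.

On these data alone, whether a longer chain or an amine in place of pent-1-en-1-yl on this carbonyl carbon would give a step beyond the scatter stays open.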